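The compounds below may be only part of what the source reports. "The series", "measured", "known", "first", "only" and "open" are said of these compounds alone.

Measured compounds:
compound 1 `CCc1ccc(-c2ccc(-c3ccc(C(=N)N)cc3)o2)cc1`, 202 nM
compound 2 `N=C(N)c1ccc(-c2ccc(-c3cccc([N+](=O)[O-])c3)o2)cc1`, 14.5 nM

Both were examined in an assay on isolated protein for inhibition of ribosyldihydronicotinamide dehydrogenase [quinone] (Homo sapiens), read by spectrophotometry, with a stated time of 1 min, in the absence of a further agent; on this read-out lower numbers stand for stronger inhibition and higher numbers for weaker inhibition. Compound 1 gives 202 nM, the highest of the two numbers and so the weaker inhibitor of the pair. Compound 2 gives 14.5 nM, a lower number whose gap to compound 1 lies well beyond the usual scatter of such measurements, so compound 2 is the clearly stronger of the two. The pair shares the same core and differs only in what sits on the outer six-membered ring; no single-step comparison connects them, so their two values are simply what is known.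

Compound 3 `CC(C)(C)c1ccc(-c2ccc(-c3ccc(C(=N)N)cc3)o2)cc1` has not been measured. It differs from compound 1 by tert-butyl in place of ethyl on an aromatic carbon. Among the measured compounds shown here, no measured pair in this set shows the effect of such a change, so there is nothing to lean on. Exchanging one short carbon group for a somewhat bulkier one is expected to move the number only a little, and the step expected here is a 1.3-fold higher number from compound 1 to compound 3 (0.11 log units; within the scatter), within the scatter or just past it. Compound 3 is therefore expected to give 260 nM, with a likely range from 100 nM to 700 nM.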

Compound 3, half-maximal inhibitory concentration: 510 nM
Compound 3: the middle estimate sits 2.0-fold (0.29 log units) below what was measured; low and high end bracket the measured number.
By their numbers in this assay, from the lowest: compound 2; then compound 1; then compound 3.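

In this assay the exchange of ethyl for tert-butyl on an aromatic carbon, para to a large group, gives a 2.5-fold higher number from compound 1 to compound 3 (0.40 log units; beyond the scatter) as a modest but real step. Among the compounds shown here, this is the first comparison here in which only one place changes, and it shows that this position does not accept every plain carbon group equally: going from 2 to 4 heavy atoms, with no hydrogen-bond donor, acceptor or net charge entering or leaving, is enough to weaken inhibition. Nothing available here accounts for this loss, so the reason for it remains unknown.

For the compounds shown here, two compounds give only one step, so it remains open whether the number rises steadily with the size of the carbon group or whether a smaller methyl, a longer straight butyl chain, an amine or a carboxylic acid at this position would give a lower number than ethyl does. Going by these compounds, it is also open whether the same exchange would have a similar effect at another place on this ring or on a different core.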